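The source may report more compounds than this note shows. Statements on the series, on what has been measured and on what is new or still open speak of the compounds shown alone.

Measured so far in a functional assay on MCF7 cells (Homo sapiens) for inhibition, read by sulforhodamine B assay, with a stated time of 48 h; on this read-out higher numbers stand for weaker inhibition and lower numbers for stronger inhibition:
- compound 1 `CSc1nn(-c2ccccc2)c2ncnc(N/N=C/c3ccc(Br)cc3)c12`: 10.9 nM
- compound 2 `CSc1nn(-c2ccccc2)c2ncnc(N/N=C/c3ccc(F)cc3)c12`: 7.5 nM
- compound 3 `CSc1nn(-c2ccccc2)c2ncnc(N/N=C/c3ccccc3O)c12`: 10.7 nM

Compound 2 gives the lowest of the three numbers, but both of its steps to the other two, a 1.5-fold lower number from compound 1 to compound 2 (0.16 log units; within the scatter) and a 1.4-fold higher number from compound 2 to compound 3 (0.15 log units; within the scatter), lie within the scatter, so the three compounds cannot be put in order on this read-out. Compound 4 `CSc1nn(-c2ccccc2)c2ncnc(N/N=C/c3ccc([N+](=O)[O-])cc3Cl)c12` differs from compound 2 by 2-chloro-4-nitrophenyl in place of 4-fluorophenyl on a carbon with a double bond to nitrogen. Among the measured compounds shown here, no measured step carries this exact change. For the measured compounds named here, the steps that bear on it are the exchange of one halogen for another on the aryl ring, a 1.5-fold lower number from compound 1 to compound 2 (0.16 log units; within the scatter), and the exchanges of the whole aryl substitution pattern, a 1.4-fold higher number from compound 2 to compound 3 (0.15 log units; within the scatter) and a 1.0-fold lower number from compound 1 to compound 3 (0.01 log units; within the scatter), all of which stayed within the scatter. On that basis no step beyond the scatter is expected in this assay, in either direction; the step from compound 2 to compound 4 is estimated as a 1.3-fold higher number from compound 2 to compound 4 (0.12 log units; within the scatter). For compound 4 the expected value is 10 nM, with a range from 4 nM to 30 nM.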

Compound 4, half-maximal inhibitory concentration: 15.7 nM
For compound 4 the middle estimate is 1.6-fold (0.20 log units) below the measured one; the measured number falls inside the stated range.
By their numbers in this assay, from the lowest: compounds 2, 3, 1 and 4 (each within the scatter of the next, the first and the last beyond it).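

In this assay, among the compounds shown here, the exchange of the aryl group on the carbon with a double bond to nitrogen now gives a step beyond the scatter, a 2.1-fold higher number from compound 2 to compound 4 (0.32 log units; beyond the scatter), though a modest one and the only such step among the four compounds. The same group gives no separation from the other two aryl groups, with a 1.5-fold higher number from compound 3 to compound 4 (0.17 log units; within the scatter) and a 1.4-fold higher number from compound 1 to compound 4 (0.16 log units; within the scatter) both within the scatter, so 2-chloro-4-nitrophenyl stands apart from 4-fluorophenyl alone. No measured evidence is available to explain this step.

From the compounds shown here alone, the chloro and nitro groups enter together as one 2-chloro-4-nitrophenyl group, so the share of each in the step remains open. Also open, going by these compounds, is whether an amine or a carboxylic acid on this aryl ring would give a larger step.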